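This account rests on a few compounds, and the source may have more. Where it says the series, first, only, none or still open, it means among the compounds named here.

Measured so far in a physicochemical assay for solubility, with a stated time of 18 h, at pH 7.4; a higher number here means a more soluble compound, a lower number a less soluble compound:
compound 1 `Fc1ccc(-c2ccc3c(NCCCNCc4ccco4)ccnc3c2)cc1` — 32000 nM
compound 2 `CC(C)CCc1ccc2c(NCCCNCc3ccco3)ccnc2c1` — 4200 nM

Compound 2 stands at the lower of the two numbers; compound 1 sits above it by the step of a 7.6-fold lower number from compound 1 to compound 2 (0.88 log units; beyond the scatter), where 4-fluorophenyl gave way to isopentyl. Compound 3 `COc1ccc(-c2ccc3c(NCCCNCc4ccco4)ccnc3c2)cc1` puts an aromatic ring back at the same place: 4-methoxyphenyl in place of isopentyl on an aromatic carbon. Among the compounds with values here, only the step of a 7.6-fold lower number from compound 1 to compound 2 (0.88 log units; beyond the scatter) bears on this change, and it was modest. Since compound 3 restores a 4-substituted phenyl like compound 1, whose value is 32000 nM, a rise of about a 7.1-fold higher number from compound 2 to compound 3 (0.85 log units; beyond the scatter) is expected in this assay. Estimate for compound 3: 30000 nM, range 10000 nM to 90000 nM.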

Compound 3, solubility: 32000 nM
Estimate against measurement, compound 3: 1.1-fold (0.03 log units) below, within the range that was stated.
By their numbers in this assay, from the lowest: compound 2; then compounds 1 and 3 (each within the scatter of the next).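

In this assay, 4-methoxyphenyl in place of isopentyl on this aromatic carbon gives a 7.6-fold higher number from compound 2 to compound 3 (0.88 log units; beyond the scatter) and so shows that the lower number of compound 2 is not shared by a second 4-substituted phenyl. Methoxy in place of fluoro on that phenyl gives no change at the digits printed from compound 1 to compound 3 (within the scatter) and does not separate the two groups. No measurement on hand accounts for either step. Still open, as far as these compounds go, is whether a phenyl bearing an amine or a carboxylic acid would stay at this level. A longer chain than isopentyl at this place also remains an open case.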